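Ethyl in Place of Chloro: Expected Cytotoxicity of Compound 3

This account rests on a few compounds, and the source may have more. Where it says the series, first, only, none or still open, it means among the compounds named here.

Measured so far:
- compound 1, `Cc1cc(NC(=O)Nc2ccc(N(C)C)cc2)c2ccccc2n1`: > 25000 nM
- compound 2, `Cc1cc(NC(=O)Nc2ccc(Cl)cc2)c2ccccc2n1`: > 25000 nM

In an ADME assay on HEK293 cells (Homo sapiens) for cytotoxicity, with a stated time of 72 h (on this read-out lower numbers stand for an effect already at smaller amounts and higher numbers for an effect only at larger amounts of compound), compound 1 gives > 25000 nM, which is a limit of the assay and not a number. Compound 2 gives > 25000 nM, likewise a limit. Because both sit at the limit of > 25000 nM in this assay, at which 2 of the 2 values shown sit, the step that the two limits leave unreadable from compound 1 to compound 2 cannot be read. Compound 2 therefore stands at the limit of the assay, with no number of its own.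

Compound 3 is `CCc1ccc(NC(=O)Nc2cc(C)nc3ccccc23)cc1`. It differs from compound 2 in one place: ethyl in place of chloro on an aromatic carbon. For the measured compounds named here, the only measured step that touches this part of the structure is a step that the two limits leave unreadable from compound 1 to compound 2, and its size is not readable, so it gives no direction for the change to ethyl. No step beyond the usual scatter is expected in this assay, and compound 3 is expected to sit at the same limit as compound 2.

For compound 3 the estimated step is a step that the limit leaves unreadable from compound 2 to compound 3. The estimated value of compound 3 is 30000 nM, within a range from 10000 nM to 100000 nM.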

Compound 3, half-maximal effective concentration: 16000 nM
The estimate for compound 3 lay 1.9-fold (0.27 log units) above the measured number; the measured number falls inside the stated range.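

In this assay, for the compounds shown here, compound 3 gives 16000 nM, which makes it the only one of the three compounds with a real number rather than a limit, so this position on the ring now has one readable value. Ethyl in place of chloro gives an at least 1.5-fold lower number from compound 2 to compound 3 (0.19 log units; that floor lies within the scatter), and ethyl in place of dimethylamino gives an at least 1.5-fold lower number from compound 1 to compound 3 (0.19 log units; that floor lies within the scatter). These two steps are only minimum sizes, the step from compound 1 to compound 2 cannot be read, and the other two values are limits of the assay and not numbers: the limit of > 25000 nM in this assay, at which 2 of the 3 values shown sit.

The compounds shown leave open whether the number would move further with a longer chain such as propyl or butyl at this position, or with a quite different group such as a carboxylic acid or a primary amine. They also leave open how far compound 3 truly lies from compound 1 and compound 2, and so whether ethyl differs at all from chloro or dimethylamino by more than repeated measurements would.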